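Series notes: phenyl fluorine removal in the thiourea pair

The source may hold more compounds than are shown below. What is called first, only, known or untested is meant among the compounds shown, and "the series" means these compounds.

Compound 3 `Fc1ccc(NC(=S)Nc2nc3ccc(F)cc3s2)cc1` gives 16200 nM in a functional assay on U-937 cells (Homo sapiens) for cytotoxicity, read by MTT assay, with a stated time of 48 h (on this read-out lower numbers stand for stronger inhibition and higher numbers for weaker inhibition), and has the lower of the two numbers measured, with compound 2 `Fc1ccc(NC(=S)Nc2nc3ccccc3s2)cc1` at 32100 nM in this assay sitting within the scatter of it. Compound 1 `Clc1ccc2nc(Nc3nc4ccccc4s3)sc2c1` gives only a limit of > 50000 nM in this assay, and the same limit is noted as the limit of > 50000 nM in this assay, at which 1 of the 3 values shown sits. The change to compound 4 `Fc1ccc2nc(NC(=S)Nc3ccccc3)sc2c1` is hydrogen in place of fluoro on an aromatic carbon; cut one bond further out, the difference reads 4-fluorophenyl to phenyl. Among the measured compounds shown here, no measured step touches this phenyl fluorine. For the measured compounds named here, the only step on record, a 2.0-fold lower number from compound 2 to compound 3 (0.30 log units; within the scatter), concerns the fluorine on the other aromatic ring and stays within the scatter, so no directly comparable evidence exists for the present change. By analogy, the step from compound 3 to compound 4 is expected to be a 1.4-fold higher number from compound 3 to compound 4 (0.13 log units; within the scatter), with no difference beyond the scatter, though a slightly higher number is the more likely side. Compound 4 is therefore estimated at 22000 nM, with a range from 9000 nM to 50000 nM in this assay.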

Compound 4, half-maximal inhibitory concentration: > 50000 nM
Compound 4: a limit, no number (the forecaster's own chance of this, stated with the estimate: 15%); at least 2.2-fold (0.35 log units) between middle value and limit.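

The phenyl fluorine matters in this pair. In this assay, among the compounds shown here, the change from 4-fluorophenyl to phenyl gives an at least 3.0-fold higher number from compound 3 to compound 4 (0.48 log units; beyond the scatter) and is the first step to pass the scatter, whereas the only earlier step, on the other aromatic ring, stayed within it. Compound 4 reads as a limit and not as a number, so the size of this step is only a floor: the limit of > 50000 nM in this assay, at which 2 of the 4 values shown sit.

Still open, as far as these compounds go, is whether this position responds to fluorine in particular or to any group there; a chlorine, a methoxy group or an amine in the same place would separate the two. Also open, from the compounds shown here alone, is whether the phenyl fluorine counts without the fluorine on the other aromatic ring: compound 2 and compound 4 differ in two places and give no reading on this.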